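Stilbene ethers with a basic chain: from amine to piperidine

The compounds below may be only part of what the source reports. "The series", "measured", "known", "first", "only" and "open" are said of these compounds alone.

The set rests on a shared stilbene ether core carrying a four-carbon chain that ends in a basic nitrogen. Among the compounds with values here, compound 1 `COc1ccccc1/C=C/c1ccccc1OCCCCN(C)C` and compound 2 `CCCN(CCC)CCCCOc1ccccc1/C=C/c1ccccc1` place the chain on a ring position that differs from the one used in compound 3 `CN(C)CCCCOc1ccc(/C=C/c2ccccc2)cc1`. In a functional assay on the whole organism with Mus musculus as the target, in the maximal electroshock model, at a dose of 50 mg/kg by the oral route (a lower number here means less inhibition, a higher number more inhibition at the dose given (going by the name of the read-out)), compound 1 gives 0%, compound 2 gives 0% and compound 3 gives 12.5%. Compound 2 is thus level with compound 1 at the digits shown, the two together forming the lowest pair of the three, while compound 3 sits a number higher that lies beyond the usual scatter.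

Compound 4 `CC1CCCN(CCCCOc2ccccc2/C=C/c2ccccc2)C1` has not yet been measured. It differs from compound 2 in one respect: 3-methylpiperidin-1-yl in place of dipropylamino on a saturated chain carbon, four bonds along the chain from an oxygen on an aromatic ring. The group that leaves and the group that enters match in their atom count and in their single hydrogen-bond acceptor; what changes is that the entering group closes into a ring.

Within the data shown here, no measured pair within the set tests this kind of exchange, so the expected step from compound 2 to compound 4 in this assay is a number 8 percentage points higher from compound 2 to compound 4 (within the scatter), small and at most modestly upward. For compound 4 the estimate is 8%, with a range from 0% to 30%.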

Compound 4, a percentage reported as inhibition, in the whole organism at one dose (the size of the read-out at that dose, not a potency): 12.5%
Compound 4: middle estimate off by 4.5 percentage points, on the low side; low and high end bracket the measured number.
By their numbers in this assay, from the lowest: compounds 1 and 2 (each within the scatter of the next); then compounds 3 and 4 (each within the scatter of the next).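

In this assay, within the data shown here, 3-methylpiperidin-1-yl in place of dipropylamino on a saturated chain carbon, four bonds along the chain from an oxygen on an aromatic ring, gives a number 12.5 percentage points higher from compound 2 to compound 4 (beyond the scatter) and so provides the first step in the set that changes only one place. The two groups match in their counts of heavy atoms and hydrogen-bond acceptors, so the end of the chain can shift this read-out, modestly, even when those counts stay the same and the entering group closes into a ring. No measurement shown accounts for the step, which leaves its origin unexplained.

On these data alone, a single exchange cannot separate the ring from its methyl group, so it remains open whether plain piperidin-1-yl would match compound 4, and whether a morpholine or a pyrrolidine at the chain end would do the same. As far as these compounds go, it is also open whether the gain would persist on a longer chain, or at doses other than the one tested here.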